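The compounds below may be only part of what the source reports. "The series", "measured", "known", "first", "only" and "open" are said of these compounds alone.

Measured so far:
compound 1, `CC1=C(C(=O)Nc2ccc(F)cc2)C(c2ccc([N+](=O)[O-])cc2)N=C(SCc2ccccc2)N1`: 27.3%
compound 2, `CC1=C(C(=O)Nc2ccc(F)cc2)C(c2ccc([N+](=O)[O-])cc2)N=C(SCc2cccc(Cl)c2)N1`: 12.9%

Both numbers come from a functional assay on the whole organism (artery, strain albino) with Rattus norvegicus as the target, with a stated time of 720 min, at a dose of 10 mg/kg by the oral route; a higher number here means more inhibition at the dose given (going by the name of the read-out), a lower number less inhibition. For the measured compounds named here, compound 2 stands lowest of the two, and the only step in the set, a number 14.4 percentage points lower from compound 1 to compound 2 (beyond the scatter), separates it from compound 1. Compound 3, `CC1=C(C(=O)Nc2ccc(F)cc2)C(c2ccc([N+](=O)[O-])cc2)N=C(SCc2ccc(F)cc2)N1`, has not yet been measured. The change from compound 2 is 4-fluorophenyl in place of 3-chlorophenyl on a saturated chain carbon bound to a sulfur. Going by the values given here, no measured step covers a swap of one halogen-bearing benzyl group for another; the one step that touches this benzyl group, from compound 1 to compound 2, concerns chloro in place of hydrogen and went down by a modest amount. Compound 3 therefore sits between a hydrogen-bearing and a chloro-bearing neighbour with nothing to anchor it, and a small rise or no change beyond the scatter is expected, a number 7.1 percentage points higher from compound 2 to compound 3 (within the scatter). For compound 3 the estimate in this assay is 20%, within a range from 5% to 35%.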

Compound 3, a percentage reported as inhibition, in the whole organism at one dose (the size of the read-out at that dose, not a potency): 19.6%
Compound 3: middle estimate off by 0.4 percentage points, on the high side; low and high end bracket the measured number.
By their numbers in this assay, from the lowest: compounds 2, 3 and 1 (each within the scatter of the next, the first and the last beyond it).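

In this assay the benzyl group on the sulfur can carry a halogen without a clear loss: fluoro in place of hydrogen gives a number 7.7 percentage points lower from compound 1 to compound 3 (within the scatter), whereas the chloro step from the earlier pair went beyond the scatter. Putting 4-fluorophenyl in place of 3-chlorophenyl on the saturated chain carbon bound to the sulfur gives a number 6.7 percentage points higher from compound 2 to compound 3 (within the scatter), so this swap cannot be told apart from no change, and as the halogen and its place differ together, neither can be judged alone. Nothing measured here speaks to what lies behind these numbers.

A 4-chlorobenzyl or a 3-fluorobenzyl group would be needed to separate the halogen from its place. From the compounds shown here alone, what a longer alkyl chain on the sulfur, or a benzyl group carrying an amine or a carboxylic acid, would do remains open.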